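Aryl exchange on the sulfur of a benzamide series

This account rests on a few compounds, and the source may have more. Where it says the series, first, only, none or still open, it means among the compounds named here.

Measured compounds:
Compound 1 `Nc1ccccc1NC(=O)c1ccc(CSc2ccc(Br)cc2)cc1`: 25.3%
Compound 2 `Nc1ccccc1NC(=O)/C=C/c1ccc(CSc2ccc(Cl)cc2)cc1`: 16.5%
Compound 3 `Nc1ccccc1NC(=O)/C=C/c1ccc(CSc2cccc3ccccc23)cc1`: 18.3%

In a functional assay on SMMC-7721 cells (Homo sapiens) for inhibition, read by CCK-8 assay, with a stated time of 72 h, tested at 8 uM (a higher number here means more inhibition of growth at the concentration tested, a lower number less inhibition of growth), compound 1 gives 25.3%. Compound 2 gives 16.5% and compound 3 gives 18.3%, so compound 1 stands at the top of the three numbers only by margins that lie within the scatter; no ordering can be read from them.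

Compound 4 `Cc1cc(C)cc(SCc2ccc(C(=O)Nc3ccccc3N)cc2)c1` has not yet been measured. It differs from compound 1 in one place: 3,5-dimethylphenyl in place of 4-bromophenyl on a sulfur.

Among the compounds with values here, one measured step bears on this kind of change, an exchange of the aryl group on the sulfur: a number 1.8 percentage points higher from compound 2 to compound 3 (within the scatter). Within the data shown here, that step was within the scatter, and there is no other step across a group on the sulfur to set against it. On that basis no step beyond the scatter is expected in this assay from compound 1 to compound 4, in either direction.

For compound 4 the estimated value is 24%, expected to fall between 12% and 36%, which means an expected step of a number 1.3 percentage points lower from compound 1 to compound 4 (within the scatter).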

Compound 4, percent growth inhibition at one concentration: 85.1%
Compound 4: middle estimate off by 61.1 percentage points, on the low side, outside the stated range (above it).
By their numbers in this assay, from the lowest: compounds 2, 3 and 1 (each within the scatter of the next); then compound 4.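

In this assay, within the data shown here, the aryl group on the sulfur proves able to decide the read-out, which the earlier compounds gave no sign of: 3,5-dimethylphenyl in place of 4-bromophenyl gives a number 59.8 percentage points higher from compound 1 to compound 4 (beyond the scatter) on the core of compound 1. Among these compounds, the only earlier exchange at this place, a number 1.8 percentage points higher from compound 2 to compound 3 (within the scatter) on a different core, therefore says little about how far this position can move the number. The two groups match in ring type, hydrogen-bond donors and acceptors, and net charge, and no measurement shown accounts for the step.

On these data alone, it remains open whether the two methyl groups or the absence of the bromine carries the step, which an unsubstituted phenyl or a group with methoxy in place of methyl could test. As far as these compounds go, whether 3,5-dimethylphenyl does the same on the core of compound 2 also remains open.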